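The compounds below may be only part of what the source reports. "The series", "measured", "known", "first", "only" and "open" are said of these compounds alone.

Among the compounds with values here, compound 1 `O=C1C(Nc2ccc(Br)cc2)=CC(=O)c2c1nc1n2[C@H]2OC[C@@H](O)[C@H]2OC1` is one of three compounds measured in a functional assay on HeLa cells (Homo sapiens) for inhibition, read by sulforhodamine B assay; a lower number here means a stronger inhibitor, a higher number a weaker inhibitor; compound 1 gives 5220 nM, the second highest of the three numbers, with compound 3 `O=C1C=C(Nc2cccc(Cl)c2)C(=O)c2c1nc1n2[C@H]2OC[C@@H](O)[C@H]2OC1` closest at 6040 nM and compound 2 `CCOc1ccc(NC2=CC(=O)c3nc4n(c3C2=O)[C@H]2OC[C@@H](O)[C@H]2OC4)cc1` furthest at 3110 nM, both gaps within the scatter. Compound 4 `O=C1C(Nc2cccc(Cl)c2)=CC(=O)c2c1nc1n2[C@H]2OC[C@@H](O)[C@H]2OC1` is not yet measured. It differs from compound 1 by 3-chlorophenyl in place of 4-bromophenyl on an amine nitrogen. Within the data shown here, the only measured step that bears on a change of the aryl group on the amine nitrogen is a 1.9-fold higher number from compound 2 to compound 3 (0.29 log units; within the scatter), which stays within the scatter, though it starts from a different aryl group and a different core arrangement. No change beyond the scatter is therefore expected here; compound 4 is estimated at 5500 nM (range 2500 nM to 12000 nM), a step of a 1.1-fold higher number from compound 1 to compound 4 (0.02 log units; within the scatter).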

Compound 4, half-maximal inhibitory concentration: 7970 nM
The estimate for compound 4 lay 1.4-fold (0.16 log units) below the measured number, within the range that was stated.
By their numbers in this assay, from the lowest: compounds 2, 1, 3 and 4 (each within the scatter of the next, the first and the last beyond it).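

In this assay, replacing 4-bromophenyl with 3-chlorophenyl on the amine nitrogen gives a 1.5-fold higher number from compound 1 to compound 4 (0.18 log units; within the scatter), the first step read directly on the core of compound 1. On this core, the exchange therefore cannot be told apart from no change. No supporting data bear on this result.

The halogen and its place on the ring change together here, so neither is read alone. Going by these compounds, how this position responds to a group other than halogen-bearing phenyl, such as pyridyl, cyclohexyl or benzyl, remains open.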